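This account rests on a few compounds, and the source may have more. Where it says the series, first, only, none or still open, it means among the compounds named here.

In a functional assay on THP-1 cells (Homo sapiens) for inhibition, read by sulforhodamine B assay, with a stated time of 48 h (a lower number here means a stronger inhibitor, a higher number a weaker inhibitor), compound 1 `O=c1c([C@@H]2C[C@H](c3ccccc3)ON2c2ccccc2)coc2cc(Cl)c(Cl)cc12` gives 38000 nM and sits within the usual scatter of compound 3 `O=C1[C@H]2[C@H](ON(c3ccccc3)[C@@H]2c2coc3ccc(F)cc3c2=O)C(=O)N1c1ccccc1` at 43500 nM on the same scale. Compound 2 `CCO[C@H]1C[C@@H](c2coc3ccc(F)cc3c2=O)N(c2ccccc2)O1` also carries an ethoxy group and gives > 60000 nM as a limit only. Compound 4 `CCO[C@H]1C[C@@H](c2coc3cc(Cl)c(Cl)cc3c2=O)N(c2ccccc2)O1` keeps the core of compound 1 but has ethoxy in place of phenyl on a saturated ring carbon. Among the compounds with values here, no measured pair isolates this change, so the only guide is compound 2 with its limit of > 60000 nM pointing toward a higher number. A modest expected step of a 1.3-fold higher number from compound 1 to compound 4 (0.10 log units; within the scatter) follows in that direction. For compound 4 the estimate is 48000 nM with an expected range of 22000 nM to 90000 nM and a reading at the limit remains possible.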

Compound 4, half-maximal inhibitory concentration: 16500 nM
The estimate for compound 4 lay 2.9-fold (0.46 log units) above the measured number, outside the stated range (below it).
By their numbers in this assay, from the lowest: compound 4; then compounds 1 and 3 (each within the scatter of the next). At a limit, above all of these: compound 2.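

Within this assay, ethoxy in place of phenyl on a saturated ring carbon gives a 2.3-fold lower number from compound 1 to compound 4 (0.36 log units; beyond the scatter), so the core of compound 1 does not need the phenyl at this position to inhibit. Ethoxy alone therefore does not bring the weak reading of compound 2, whose value remains only a limit: the limit of > 60000 nM in this assay, at which 1 of the 4 values shown sits.

This single pair cannot separate losing the phenyl ring from gaining the oxygen. As far as these compounds go, whether a propyl chain, a longer alkoxy chain or an amine at this carbon would give a lower number remains open.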